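Chloro to methyl in the fluoro amide

A few compounds are considered here, and "the series" means these few. Any claim that something is new, unique, unknown or untested is made for them only; others in the source may bear on it.

In a physicochemical assay for solubility, read by nephelometry, measured as kinetic solubility, at pH 6.5, tested at 10 mg/mL (a higher number here means a more soluble compound, a lower number a less soluble compound), compound 1 (`Cc1ccccc1C(=O)Nc1cc(Cl)ccn1`) gives 12.5 ug/mL, compound 2 (`Cc1c(F)cccc1C(=O)Nc1cc(Cl)ccn1`) gives 12.5 ug/mL and compound 3 (`Cc1ccccc1C(=O)Nc1ccc(C#N)cn1`) gives 6.3 ug/mL. Compound 2 stands level with compound 1, and all three lie within the scatter of one another. Compound 4 (`Cc1ccnc(NC(=O)c2cccc(F)c2C)c1`) differs from compound 2 by methyl in place of chloro on an aromatic carbon, opposite the ring nitrogen. Going by the values given here, the only measured step in one place, no change at the digits printed from compound 1 to compound 2 (within the scatter), is a fluoro in place of hydrogen, and no measured step covers this exchange. Among the compounds with values here, with that step as the sole guide, the expected change in this assay is a 1.3-fold higher number from compound 2 to compound 4 (0.11 log units; within the scatter), which stays within the scatter. Compound 4 is estimated at 16 ug/mL, with an expected range of 6 ug/mL to 45 ug/mL.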

Compound 4, solubility: 25 ug/mL
Beside the measured number, compound 4's estimate is 1.6-fold (0.19 log units) below it; low and high end bracket the measured number.
By their numbers in this assay, from the lowest: compounds 3, 1, 2 and 4 (each within the scatter of the next, the first and the last beyond it).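

In this assay, methyl in place of chloro opposite the ring nitrogen gives a 2.0-fold higher number from compound 2 to compound 4 (0.30 log units; within the scatter) with the rest of the structure unchanged. Going by these compounds alone, this is the first measured step at this position, and it leaves the exchange inside the scatter even though compound 4 holds the top place in the printed order. Nothing available bears on the origin of this step. Going by these compounds, whether an amine, a methoxy group or a carboxylic acid in place of methyl would take the number beyond the scatter stays open. So does whether the same exchange gives a similar step on compound 1, without the fluoro.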